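Swapping 2-methoxyphenyl for 4-methoxyphenyl: what to expect

The source may report more compounds than this note shows. Statements on the series, on what has been measured and on what is new or still open speak of the compounds shown alone.

Compound 1 `COc1cc(/C=C/C(=O)/C=C/c2cccc3ccccc23)ccc1OCc1cn(CCOc2cc(=O)oc3ccccc23)nn1` gives 6540 nM
Compound 2 `COc1ccccc1/C=C/C(=O)/C=C/c1ccc(OCc2cn(CCOc3cc(=O)oc4ccccc34)nn2)c(OC)c1` gives 9490 nM
Compound 3 `COc1ccc(/C=C/C(=O)/C=C/c2ccc(OCc3cn(CCOc4cc(=O)oc5ccccc45)nn3)c(OC)c2)cc1` is not yet measured

Among the measured compounds shown here, in a functional assay on HCT-116 cells (Homo sapiens) for cytotoxicity, read by sulforhodamine B assay, with a stated time of 48 h (on this read-out lower numbers stand for stronger inhibition and higher numbers for weaker inhibition), compound 2 gives 9490 nM and so lies within the scatter of compound 1, the only other measured compound. The change to compound 3 reads 4-methoxyphenyl in place of 2-methoxyphenyl on a double-bonded chain carbon bound to a double-bonded chain carbon and keeps the same atoms, joined differently: 4-methoxyphenyl in place of 2-methoxyphenyl on a double-bonded chain carbon bound to a double-bonded chain carbon. One measured step (a 1.5-fold higher number from compound 1 to compound 2 (0.16 log units; within the scatter)) bears on this place. It swaps naphthalen-1-yl for 2-methoxyphenyl and stays within the scatter. For the measured compounds named here, no measured step tests 4-methoxyphenyl itself, so the expectation rests on that single step. In this assay the expected step (a 1.1-fold lower number from compound 2 to compound 3 (0.05 log units; within the scatter)) is none beyond the scatter. For compound 3 the estimated value is 8500 nM with an expected range from 3500 nM to 20000 nM on this read-out.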

Compound 3, half-maximal inhibitory concentration: 9290 nM
The estimate for compound 3 lay 1.1-fold (0.04 log units) below the measured number; measured number inside the range.
By their numbers in this assay, from the lowest: compounds 1, 3 and 2 (each within the scatter of the next).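

In this assay, 4-methoxyphenyl in place of 2-methoxyphenyl gives a 1.0-fold lower number from compound 2 to compound 3 (0.01 log units; within the scatter) and so shows that, with the same atoms joined differently, this change on a double-bonded chain carbon bound to a double-bonded chain carbon does not move the number beyond the scatter. The comparison with the larger aromatic group gives the same picture: 4-methoxyphenyl in place of naphthalen-1-yl gives a 1.4-fold higher number from compound 1 to compound 3 (0.15 log units; within the scatter) and also stays within the scatter. Three different aromatic groups at this place now read alike, where earlier only two could be compared.

On these data alone, whether a phenyl ring carrying an amine or a carboxylic acid at this place would also read alike remains open. Nothing available here explains why these three groups read so alike.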